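Hydroxymethyl on compound 2: what to expect

The source may hold more compounds than are shown below. What is called first, only, known or untested is meant among the compounds shown, and "the series" means these compounds.

compound 1 `Cc1cc(F)cnc1N1CCN(C(=O)CCCc2cccc3ncoc23)[C@@H](C)C1`: 0%
compound 2 `Cc1cc(F)cnc1N1CCN(C(=O)CCCc2cccc3ncccc23)[C@@H](C)C1`: 0.2%
compound 3 `Cc1cc(F)cnc1N1CCN(C(=O)CCCc2cccc3ncncc23)[C@@H](C)C1`: 0%

These three compounds share one core and differ only in the ring group carried on the chain. All of the values come from an ADME assay on microsomes from liver (Rattus norvegicus) for metabolic stability, read by LC-MS, with a stated time of 15 min, tested at 1 uM; a lower number here means that less of the compound is left, a higher number that more of the compound is left. Compound 2 gives 0.2%, and this cannot be told apart from the other two values, so almost nothing is left of any of them.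

Compound 4 `Cc1cc(F)cnc1N1CCN(C(=O)CCCc2cccc3ncc(CO)cc23)[C@@H](C)C1` keeps everything in compound 2 except for one change: hydroxymethyl in place of hydrogen on an aromatic carbon. The hydroxymethyl stands in place of hydrogen on an aromatic carbon, two atoms from the ring nitrogen.

For the measured compounds named here, three measured steps bear on this, though only indirectly, since each swaps the whole ring group: a number 0.2 percentage points higher from compound 1 to compound 2 (within the scatter), no change at the digits printed from compound 1 to compound 3 (within the scatter) and a number 0.2 percentage points lower from compound 2 to compound 3 (within the scatter). None of them adds a hydroxymethyl, so the data hold no direct measure of this change. Compound 2 at 0.2% has almost no room to fall, so any movement can only be upward.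

The expected result is no step beyond the scatter, with an estimated a number 1.8 percentage points higher from compound 2 to compound 4 (within the scatter). For compound 4 the estimated value in this assay is 2%, with an expected range of 0% to 10%.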

Compound 4, percent of the compound remaining: 1%
Compound 4: the middle estimate sits 1 percentage points above what was measured, and the stated range covers the measured number.
By their numbers in this assay, from the lowest: compounds 1, 3, 2 and 4 (each within the scatter of the next).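

Compound 4 gives the first direct measure of this change: in this assay, hydroxymethyl in place of hydrogen on an aromatic carbon, two atoms from the ring nitrogen, gives a number 0.8 percentage points higher from compound 2 to compound 4 (within the scatter). The earlier compounds shown here only swapped the whole ring group, whereas this step adds one small group to a single ring carbon of compound 2 and leaves everything else in place. Even so, the added group does not bring the compound clear of the scatter, so at this position hydroxymethyl does not separate compound 4 from compound 2, and almost nothing is left of either; no measurement at hand offers an explanation for this result.

The compounds shown leave open whether a different group on this same ring carbon, such as an amine, a carboxylic acid or a longer chain like hydroxyethyl, would leave more of the compound intact. They also leave open whether hydroxymethyl would have any larger effect on another ring carbon or elsewhere on the shared core.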